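Replacing an Aryl Amide with an Anilide on a Shared Core

A few compounds are considered here, and "the series" means these few. Any claim that something is new, unique, unknown or untested is made for them only; others in the source may bear on it.

Measured compounds in a functional assay on HL-60 cells (Homo sapiens) for antiproliferative activity, read by MTT assay, with a stated time of 72 h; on this read-out higher numbers stand for weaker inhibition and lower numbers for stronger inhibition:
- compound 1 `CN(C(=O)c1ccc(Cl)cc1)c1ccc2[nH]c(-c3n[nH]c4ccccc34)cc2n1`: 450 nM
- compound 2 `COc1cccc(C(=O)N(C)c2ccc3[nH]c(-c4n[nH]c5ccccc45)cc3n2)c1`: 1420 nM
- compound 3 `CN(C(=O)c1ccccc1)c1ccc2[nH]c(-c3n[nH]c4cc(C#N)ccc34)cc2n1`: 6430 nM

Compound 2 gives the second highest of these three numbers. Its nearest neighbour is compound 1, whose number is lower, and the furthest is compound 3, whose number is higher; both gaps lie beyond the usual scatter.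

Compound 4 `CN(C(=O)Nc1ccccc1)c1ccc2[nH]c(-c3n[nH]c4ccccc34)cc2n1` has not yet been tested. It differs from compound 2 in one place: anilino in place of 3-methoxyphenyl on a carbonyl carbon. Seen from one bond further out, the (3-methoxyphenyl)carbonyl group becomes a phenylcarbamoyl group, so the carbonyl carbon now carries a nitrogen-linked ring instead of a directly attached one.

Among the compounds with values here, only one measured step touches this position: a 3.2-fold higher number from compound 1 to compound 2 (0.50 log units; beyond the scatter). That step swapped one substituted phenyl for another and moved the number by a modest amount. Within the data shown here, no measured pair shows what inserting a nitrogen between the carbonyl carbon and the ring does, so the direction of the change for compound 4 cannot be read from the data. A step of roughly the size seen between compound 1 and compound 2 is expected, in either direction, which for compound 4 means an estimated 1500 nM (range 400 nM to 5500 nM), a change of about a 1.1-fold higher number from compound 2 to compound 4 (0.02 log units; within the scatter).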

Compound 4, half-maximal inhibitory concentration: 8.3 nM
For compound 4 the middle estimate is 180-fold (2.26 log units) above the measured one, outside the stated range (below it).
By their numbers in this assay, from the lowest: compound 4; then compound 1; then compound 2; then compound 3.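

In this assay, anilino on the carbonyl carbon in place of 3-methoxyphenyl gives a 170-fold lower number from compound 2 to compound 4 (2.23 log units; beyond the scatter), and anilino in place of 4-chlorophenyl gives a 54-fold lower number from compound 1 to compound 4 (1.73 log units; beyond the scatter). Both steps are far larger than the earlier swap of one substituted phenyl for the other, a 3.2-fold higher number from compound 1 to compound 2 (0.50 log units; beyond the scatter), so this position can respond much more strongly to the change from a directly attached ring to a nitrogen-linked ring than that swap suggested, although the ring in anilino also carries no substituent. No measurement shown here accounts for the size of these steps.

The compounds shown leave open how much of the effect belongs to the added nitrogen and its hydrogen, and how much to the unsubstituted ring, since no anilino compound with a chlorine or methoxy group on its ring appears among them. An N-methylanilino or benzylamino group on the same carbonyl carbon would show whether a ring-bearing nitrogen alone is enough, or whether the hydrogen on that nitrogen and the length of the link also count.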